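The source may report more compounds than this note shows. Statements on the series, on what has been measured and on what is new or still open speak of the compounds shown alone.

Measured compounds in a functional assay on SW1573 cells (Homo sapiens) for inhibition, read by sulforhodamine B assay, with a stated time of 48 h; a higher number here means a weaker inhibitor of growth, a lower number a stronger inhibitor of growth:
Compound 1, `O=C(/C(=C/c1ccccc1)CCl)c1ccccc1`: in this assay compound 1 gives 3600 nM.
Compound 2, `CC(=O)OC/C(=C\C1CCCCC1)C(=O)c1ccccc1`: in this assay compound 2 gives 19000 nM.
Compound 3, `CCC(/C=C(\COC(C)=O)C(=O)c1ccccc1)CC`: in this assay compound 3 gives 77000 nM.

Compound 3 stands highest of the three numbers, so it is the weakest grower-inhibitor here; compound 2 is its nearest neighbour and compound 1 lies furthest below it. The step to compound 4, `CC(=O)OC/C(=C\c1ccccc1)C(=O)c1ccccc1`, is phenyl in place of pentan-3-yl on a double-bonded chain carbon bound to a double-bonded chain carbon. Going by the values given here, one measured step bears directly on this position: a 4.1-fold higher number from compound 2 to compound 3 (0.61 log units; beyond the scatter), where a ring gave way to an open chain and the number rose. Compound 4 puts a ring back at the same place, and compound 1, which also carries a phenyl there though with a different group on the other chain carbon, gives the lowest number of the set. Taken together these point to a drop in this assay for compound 4, expected to be at least as large as the step from compound 2 to compound 3 and possibly larger. The expected step for compound 4 is a 7.7-fold lower number from compound 3 to compound 4 (0.89 log units; beyond the scatter). The estimate for compound 4 is therefore 10000 nM, within a range from 3000 nM to 35000 nM.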

Compound 4, concentration for 50% growth inhibition: 4800 nM
Compound 4: the middle estimate sits 2.1-fold (0.32 log units) above what was measured; the measured number falls inside the stated range.
By their numbers in this assay, from the lowest: compounds 1 and 4 (each within the scatter of the next); then compound 2; then compound 3.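

Read in this assay with the acetoxy group held constant, phenyl in place of pentan-3-yl gives a 16-fold lower number from compound 3 to compound 4 (1.21 log units; beyond the scatter) and so more than reverses the earlier rise seen on leaving the cyclohexyl ring. Phenyl in place of cyclohexyl gives a 4.0-fold lower number from compound 2 to compound 4 (0.60 log units; beyond the scatter) as a separate step, so having a ring at this place does not by itself set the number, and the order from lowest is phenyl, cyclohexyl, pentan-3-yl. With phenyl in place, acetoxy in place of chloro gives a 1.3-fold higher number from compound 1 to compound 4 (0.12 log units; within the scatter) and leaves compound 1 and compound 4 indistinguishable in this assay.

No measurement shown here explains why these groups differ. Going by these compounds, how a pyridine ring, or a phenyl carrying a methoxy group, would behave at this place remains open.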